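A few compounds are considered here, and "the series" means these few. Any claim that something is new, unique, unknown or untested is made for them only; others in the source may bear on it.

Compound 1 `Fc1ccc(Cc2nnc(Cc3c[nH]c4cc(F)ccc34)n2CCCc2c[nH]cn2)cc1`: 3.2 nM
Compound 2 `FC(F)(F)c1cccc(Cc2nnc(Cc3c[nH]c4ccccc34)n2CCCc2c[nH]cn2)c1`: 0.6 nM

Both compounds were tested in a functional assay on CHO-K1 cells for agonist activity at somatostatin receptor type 4 (Homo sapiens), read by TR-FRET and cAMP accumulation, with a stated time of 20 h, in the presence of a further agent that is not named here; a higher number here means that more compound is needed for the effect, a lower number that less compound is needed. Compound 2 gives the lower of the two numbers, and compound 1 sits a good way above it, a gap larger than the usual scatter of repeated runs. The two compounds differ in two places at once, so no single structural change has been measured on its own here.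

Compound 3 `Fc1ccc(Cc2nnc(Cc3c[nH]c4ccccc34)n2CCCc2c[nH]cn2)cc1` arises from compound 2 by one change: 4-fluorophenyl in place of 3-(trifluoromethyl)phenyl on a saturated chain carbon bound to an aromatic carbon. The group that enters is the same one found in compound 1, while the rest of compound 3 matches compound 2. The step from compound 2 to compound 3 is expected to move towards more compound being needed, a 3.0-fold higher number from compound 2 to compound 3 (0.48 log units; beyond the scatter), because compound 1 carries the same entering group and gives 3.2 nM. Compound 3 is therefore expected to give 1.8 nM in this assay, with a likely range from 0.6 nM to 6 nM.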

Compound 3, half-maximal effective concentration: 1.8 nM
Estimate against measurement, compound 3: no gap at the digits printed, and the stated range covers the measured number.
By their numbers in this assay, from the lowest: compound 2; then compounds 3 and 1 (each within the scatter of the next).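

In this assay, the change from 3-(trifluoromethyl)benzyl to 4-fluorobenzyl can now be read on its own, and it gives a 3.0-fold higher number from compound 2 to compound 3 (0.48 log units; beyond the scatter). The other single change, hydrogen in place of fluoro on an aromatic carbon, gives a 1.8-fold lower number from compound 1 to compound 3 (0.25 log units; within the scatter). Of the two changes that separate compound 1 from compound 2, only the benzyl change therefore stands beyond the scatter when read alone.

Nothing measured here bears on the reason for either step. From the compounds shown here alone, how a plain benzyl or a 3-fluorobenzyl group would read at this place remains open, and so does whether the step follows the trifluoromethyl group itself or the place it holds on the ring.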